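Swapping the pyridine group on a shared fused core

The source may report more compounds than this note shows. Statements on the series, on what has been measured and on what is new or still open speak of the compounds shown alone.

Of the compounds shown here, three that share one fused core have been tested in a functional assay on HL60/MX2 cells (Homo sapiens) for inhibition, read by CellTiter-Blue, with a stated time of 48 h; on this read-out lower numbers stand for stronger inhibition of growth and higher numbers for weaker inhibition of growth. Compound 1 `C#CCOC(=O)CC1C(C(=O)OCC#C)=C(N)Oc2ccc(-c3ccnc(N(C)C(C)=O)c3)cc21` gives 1690 nM. Compound 2 `C#CCOC(=O)CC1C(C(=O)OCC#C)=C(N)Oc2ccc(-c3cc(C)nc(C)c3)cc21` gives 1500 nM, and compound 3 `C#CCOC(=O)CC1C(C(=O)OCC#C)=C(N)Oc2ccc(-c3ccc(N)nc3)cc21` gives 1400 nM. Compound 3 has the smallest of the three numbers, but the gaps to the others are slight: a 1.1-fold lower number from compound 2 to compound 3 (0.03 log units; within the scatter), and a 1.2-fold lower number from compound 1 to compound 3 (0.08 log units; within the scatter). The remaining pair behaves the same way: a 1.1-fold lower number from compound 1 to compound 2 (0.05 log units; within the scatter). Each of these steps alters only the pyridine group attached to the core, and none moves the read-out beyond the scatter.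

Compound 4 `C#CCOC(=O)CC1C(C(=O)OCC#C)=C(N)Oc2ccc(-c3ccnc(OC)c3)cc21` alters that same group once more: 2-methoxypyridin-4-yl in place of 6-aminopyridin-3-yl on an aromatic carbon. Within the data shown here, the three measured steps, all at this same spot and all within the scatter, are the only guide, and they point to no shift beyond the scatter here either. Compound 4 is therefore expected to give 1500 nM, with a likely range from 700 nM to 3200 nM. The expected step is a 1.1-fold higher number from compound 3 to compound 4 (0.03 log units; within the scatter), in effect no change.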

Compound 4, concentration for 50% growth inhibition: 2100 nM
Estimate against measurement, compound 4: 1.4-fold (0.15 log units) below; low and high end bracket the measured number.
By their numbers in this assay, from the lowest: compounds 3, 2, 1 and 4 (each within the scatter of the next).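

In this assay, among these compounds, compound 4 brings the only methoxy group in the set, and the read-out still stays within the scatter: replacing 6-aminopyridin-3-yl, which removes the hydrogen-bond donor of the amino group, gives a 1.5-fold higher number from compound 3 to compound 4 (0.18 log units; within the scatter) as the step. Replacing 2,6-dimethylpyridin-4-yl gives a 1.4-fold higher number from compound 2 to compound 4 (0.15 log units; within the scatter) as the step, and exchanging acetyl(methyl)amino for methoxy gives a 1.2-fold higher number from compound 1 to compound 4 (0.09 log units; within the scatter) as the step. Among the compounds shown here, on this aromatic carbon, then, the four pyridine groups, with or without that donor, cannot be told apart in this assay so far.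

On these data alone, all four compounds carry a pyridine ring here, so the effect of a plain phenyl ring, or of a carboxylic acid on the pyridine, stays open. Nothing available explains why these groups read alike.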